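The source may hold more compounds than are shown below. What is called first, only, known or untested is meant among the compounds shown, and "the series" means these compounds.

Working notes on the series. Compound 1 `CCN(CC)S(=O)(=O)c1ccc(S(=O)(=O)N2CCC[C@@H](C(=O)N3CCC(C(F)(F)F)CC3)C2)cc1` gives 370 nM in a functional assay on BXPC-3 cells (Homo sapiens) for inhibition, read by MTT assay, with a stated time of 7 days; on this read-out higher numbers stand for weaker inhibition and lower numbers for stronger inhibition; compound 2 `O=C([C@@H]1CCCN(S(=O)(=O)c2ccc(S(=O)(=O)C3COC3)cc2)C1)N1CCC(F)(F)CC1` gives 361 nM in this assay, and the two numbers lie within the scatter of each other, so compound 1 stands alongside compound 2 rather than apart from it. Compound 3 `CCN(CC)S(=O)(=O)c1ccc(S(=O)(=O)N2CCC[C@@H](C(=O)NC3CCOCC3)C2)cc1` differs from compound 1 by (oxan-4-yl)amino in place of 4-(trifluoromethyl)piperidin-1-yl on a carbonyl carbon. For the measured compounds named here, no measured step covers a change of this kind, so the expectation rests on the flat pair alone. A modest weakening is expected for compound 3, a 1.8-fold higher number from compound 1 to compound 3 (0.24 log units; within the scatter), possibly no larger than the scatter. Compound 3 is estimated at 650 nM, with a range from 200 nM to 2200 nM.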

Compound 3, half-maximal inhibitory concentration: 8570 nM
Compound 3: the middle estimate sits 13-fold (1.12 log units) below what was measured, outside the stated range (above it).
By their numbers in this assay, from the lowest: compounds 2 and 1 (each within the scatter of the next); then compound 3.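

For the compounds shown here, on a carbonyl carbon whose other neighbour is a saturated ring carbon, (oxan-4-yl)amino in place of 4-(trifluoromethyl)piperidin-1-yl gives a 23-fold higher number from compound 1 to compound 3 (1.36 log units; beyond the scatter) in this assay, so this position responds strongly to the change, which no earlier step showed. The entering group brings a hydrogen-bond donor and a hydrogen-bond acceptor, and the trifluoromethyl group leaves, so several features change in one step. Nothing at hand assigns the weakening to any one of them. Still open, on these data alone, is whether the amide hydrogen or the loss of trifluoromethyl matters more; morpholin-4-yl or plain piperidin-1-yl on the same carbonyl carbon would bear on that.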